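Halogen swap on an aryl-triazole oxime and its enone analogue

The source may report more compounds than this note shows. Statements on the series, on what has been measured and on what is new or still open speak of the compounds shown alone.

Two cores carry the same pendant aryl-triazole. Compound 1 `CC(C)=CCC/C(C)=C/CC/C(C)=C/CC[C@@H]1[C@@]2(C)CC/C(=N\OCc3cn(-c4ccc(F)cc4)nn3)C(C)(C)[C@@H]2CC[C@@]1(C)O` and compound 2 `CC(C)=CCC/C(C)=C/CC/C(C)=C/CC[C@@H]1[C@@]2(C)CC/C(=N\OCc3cn(-c4ccc(Cl)cc4)nn3)C(C)(C)[C@@H]2CC[C@@]1(C)O` share an oxime ether core; compound 3 `CC(C)=CCC/C(C)=C/CC/C(C)=C/CC[C@@H]1[C@@]2(C)C/C(=C\c3ccc(OCc4cn(-c5ccc(F)cc5)nn4)cc3)C(=O)C(C)(C)[C@@H]2CC[C@@]1(C)O` and the not yet measured compound 4 `CC(C)=CCC/C(C)=C/CC/C(C)=C/CC[C@@H]1[C@@]2(C)C/C(=C\c3ccc(OCc4cn(-c5ccc(Cl)cc5)nn4)cc3)C(=O)C(C)(C)[C@@H]2CC[C@@]1(C)O` share an enone core with a benzylic ether linking to the triazole. The difference between the two cores is not broken down here.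

In a functional assay on HepG2 cells (Homo sapiens) for cytotoxicity, read by MTT assay, with a stated time of 48 h (a higher number here means a weaker inhibitor, a lower number a stronger inhibitor), compound 1 gives 63100 nM and compound 2 gives 19900 nM. The change between them is chloro in place of fluoro on an aromatic carbon and it made a 3.2-fold lower number from compound 1 to compound 2 (0.50 log units; beyond the scatter). Compound 3 gives 35900 nM in this assay; this value and that of compound 1 lie within the scatter of each other, as do the values of compound 3 and compound 2, so no order among the three can be read from them.

Compound 4 carries the change (chloro in place of fluoro on an aromatic carbon), which is the same change as on the oxime ether core, placed in the same way. For the measured compounds named here, with only one prior instance on a different core, the expectation for compound 4 is taken from that single step: a step of about a 3.0-fold lower number from compound 3 to compound 4 (0.48 log units; beyond the scatter) from compound 3 to compound 4 is expected in this assay, because the same change gave a 3.2-fold lower number from compound 1 to compound 2 (0.50 log units; beyond the scatter). Going by the values given here, the estimate for compound 4 in this assay is therefore 12000 nM, expected to lie between 5000 nM and 30000 nM, with the width reflecting that the core differs from the one on which the step was seen.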

Compound 4, half-maximal inhibitory concentration: 123000 nM
Compound 4: the middle estimate sits 10-fold (1.01 log units) below what was measured; the whole stated range lies below it.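

In this assay, chloro in place of fluoro on the enone core gives a 3.4-fold higher number from compound 3 to compound 4 (0.53 log units; beyond the scatter). The halogen swap therefore does not carry from one core to the other in this series: the step on the enone core runs in the opposite direction to the step on the oxime ether core, and the two steps stand clearly apart: the same change on two cores in this assay, a 3.2-fold lower number (0.50 log units; beyond the scatter) from compound 1 to compound 2 and a 3.4-fold higher number (0.53 log units; beyond the scatter) from compound 3 to compound 4, 11-fold (1.04 log units) apart, beyond the scatter of two such steps. This shows that a step seen on one of these cores is a poor guide to the other, but with one pair per core it does not show which structural difference between the cores goes with the reversal, nor whether the reversal extends beyond these four compounds.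

From the compounds shown here alone, the cores differ in more than one place, so it remains open whether the reversal follows the oxime ether, the enone or the benzylic ether link, and a compound changing only one of these features would be needed to separate them. Going by these compounds, it is also open whether a bromo or a methyl group on the same aromatic carbon would follow the trend of the oxime ether pair or that of the enone pair.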